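The compounds below may be only part of what the source reports. "The series", "measured", "known", "first", "only" and "open" are said of these compounds alone.

Measured compounds:
- compound 1, `Cc1ccc(C2=NN(C(=O)CBr)C(c3cc(Cl)ccc3O)C2)cc1`: 5220 nM
- compound 2, `COc1ccc(C2=NN(C(=O)CN3CCCCC3)C(c3cc(Cl)ccc3O)C2)cc1`: 9650 nM

The two numbers come from an assay on isolated protein for inhibition of Amine oxidase [flavin-containing] A (Homo sapiens), read by fluorescence, with stated times of 15 min and 20 min; a higher number here means a weaker inhibitor, a lower number a stronger inhibitor. In this assay compound 1 gives 5220 nM and compound 2 gives 9650 nM; the two values lie within the usual scatter of each other, so no ordering of compound 1 and compound 2 can be read from them. Going by the values given here, compound 1 and compound 2 differ at more than one place, so no single step between them is set out here.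

Compound 3, `Cc1ccc(C2=NN(C(=O)CN3CCCCC3)C(c3cc(Cl)ccc3O)C2)cc1`, is not yet measured. It differs from compound 2 in one place: methyl in place of methoxy on an aromatic carbon, para to a large group. Compound 1 carries the same methyl, but with a different group on the acyl side, so it gives no isolated reading of this exchange. Among the compounds with values here, with no measured step for this change, no shift beyond the scatter is expected; the step from compound 2 to compound 3 is estimated at a 1.2-fold lower number from compound 2 to compound 3 (0.08 log units; within the scatter). Compound 3 is expected to give 8000 nM in this assay, within a range of 3000 nM to 22000 nM.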

Compound 3, half-maximal inhibitory concentration: 14400 nM
The estimate for compound 3 lay 1.8-fold (0.26 log units) below the measured number; measured number inside the range.
By their numbers in this assay, from the lowest: compounds 1, 2 and 3 (each within the scatter of the next, the first and the last beyond it).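

In this assay, the exchange of 4-methoxyphenyl to 4-methylphenyl now has an isolated reading with the piperidin-1-yl acyl side held constant: the step is a 1.5-fold higher number from compound 2 to compound 3 (0.17 log units; within the scatter) and so does not separate methyl from methoxy at this place, para to a large group, on this background. Going by these compounds alone, compound 3 also isolates the acyl side with the methyl held constant, giving a 2.8-fold higher number from compound 1 to compound 3 (0.44 log units; beyond the scatter) for piperidin-1-yl in place of bromo on a saturated chain carbon bound to a carbonyl carbon; this modest step is the only single-place change among the three compounds that lies beyond the scatter. No supporting measurement is available to account for the size of either step.

The compounds shown leave open whether a group other than methoxy or methyl at this aromatic place, such as fluoro or dimethylamino, would give a step beyond the scatter. They also leave open whether a morpholin-4-yl group or a longer chain between the carbonyl and the amine would give a number different from that of piperidin-1-yl.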